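The source may report more compounds than this note shows. Statements on the series, on what has been measured and on what is new or still open speak of the compounds shown alone.

Series notes. The shared core carries either an anilino group bearing a sulfonamide or a directly attached bicyclic amide. Compound 1 `CCCNS(=O)(=O)c1ccc(Nc2ncc3c(n2)N(C2CCCC2)[C@H](CC)C(=O)N3C)cc1` in a functional assay on Huh-7 cells (Homo sapiens) for antiproliferative activity, read by CCK-8 assay, with a stated time of 72 h (on this read-out higher numbers stand for weaker inhibition of growth and lower numbers for stronger inhibition of growth), gives 278 nM. Among the compounds with values here, compound 3 `CC[C@@H]1C(=O)N(C)c2cnc(Nc3ccc(S(=O)(=O)NC4CCCC4)cc3)nc2N1C1CCCC1` gives 389 nM, and the only measured step, a 1.4-fold higher number from compound 1 to compound 3 (0.15 log units; within the scatter), is a cyclopentyl in place of propyl on a sulfonamide nitrogen and stays within the scatter. Compound 2 `CCC1C(=O)N(C)c2cnc(-n3ccc4cc(C(N)=O)ccc43)nc2N1c1ccn(C)n1` stands apart: in this assay compound 2 is reported as "not active" (no number reported), so no number is available for it, and it cannot be placed against compound 1 or compound 3 on this read-out.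

Compound 4 `CCC1C(=O)N(C)c2cnc(-n3ccc4cc(C(=O)NC)ccc43)nc2N1c1ccn(C)n1` differs from compound 2 by methyl in place of hydrogen on an amide-type nitrogen. The step from compound 1 to compound 3 concerns a different part of the molecule and gives no guidance on this change. With compound 2 reported without a number, the expectation for compound 4 rests only on that report, and the change is small.

Compound 4 is therefore expected to give about 30000 nM in this assay, with a range from 5000 nM to 100000 nM, and a report without a number is the more likely outcome.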

Compound 4, concentration for 50% growth inhibition: 13200 nM
Compound 4: middle estimate off by 2.3-fold (0.36 log units), on the high side; low and high end bracket the measured number.
By their numbers in this assay, from the lowest: compounds 1 and 3 (each within the scatter of the next); then compound 4.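

Within the data shown here, compound 2 carries no number, so no step from compound 2 to compound 4 can be read. The compounds shown leave open how methylcarbamoyl compares with carbamoyl on this read-out, and which single change separates compound 4 from compounds 1 and 3. No measured evidence bears on this result.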